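From hydroxy to acetoxy in compound 2

The source may report more compounds than this note shows. Statements on the series, on what has been measured and on what is new or still open speak of the compounds shown alone.

- Compound 1 `CCC[C@H]1O[C@H](COCc2ccccc2)[C@@H](OCc2ccccc2)[C@H](OCc2ccccc2)[C@H]1O`: 23600 nM
- Compound 2 `CC(C)C[C@H]1O[C@H](COCc2ccccc2)[C@@H](OCc2ccccc2)[C@H](OCc2ccccc2)[C@H]1O`: 44500 nM

Both values come from a functional assay on HOS cells (Homo sapiens) for antiproliferative activity, read by sulforhodamine B assay; on this read-out higher numbers stand for weaker inhibition of growth and lower numbers for stronger inhibition of growth. Within the data shown here, compound 2 stands level with compound 1, the only other measured compound, so neither can be called the stronger. Compound 3 `CC(=O)O[C@@H]1[C@@H](OCc2ccccc2)[C@H](OCc2ccccc2)[C@@H](COCc2ccccc2)O[C@@H]1CC(C)C` keeps the chain of compound 2 and changes at its hydroxy: acetyl in place of hydrogen on an oxygen on a saturated carbon. In words, this is acetyl in place of hydrogen on an oxygen on a saturated carbon, or hydroxy to acetoxy. Among the measured compounds shown here, only one measured step exists, a 1.9-fold higher number from compound 1 to compound 2 (0.28 log units; within the scatter), and it changes the chain, not this oxygen. It is therefore a weak guide, and no shift beyond the scatter is expected in this assay, in either direction. The estimated step is a 1.1-fold lower number from compound 2 to compound 3 (0.05 log units; within the scatter). Compound 3 is expected at 40000 nM, with an estimated range of 15000 nM to 100000 nM.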

Compound 3, concentration for 50% growth inhibition: > 50000 nM
Compound 3: a limit, no number; the forecaster's own chance of this, stated with the estimate: 20%; middle value at least 1.2-fold (0.09 log units) from the limit.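

Compound 3 is the first compound shown with a change on this oxygen, since the earlier step altered only the chain. In this assay compound 3 gives > 50000 nM, which is a limit of the assay and not a number. Replacing the hydrogen of the hydroxy with acetyl therefore brings no sign of stronger growth inhibition, and the step has only a floor (an at least 1.1-fold higher number from compound 2 to compound 3 (0.05 log units; that floor lies within the scatter)), so its true size could lie within the scatter or beyond it, and the reading stops at this ceiling: the limit of > 50000 nM in this assay, at which 1 of the 3 values shown sits.

As far as these compounds go, whether the free hydroxy itself matters stays open, as a single capped reading cannot settle it. Also open, from the compounds shown here alone, is how an amine in place of the hydroxy, or a longer acyl group such as benzoyl on this oxygen, would read.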